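Amino replaces bromo on the aryl group of compound 2

The compounds below may be only part of what the source reports. "The series", "measured", "known", "first", "only" and "open" are said of these compounds alone.

Measured so far:
compound 1, `N#Cc1ccccc1-c1nc2cccnc2o1`: 61%
compound 2, `Brc1ccccc1-c1nc2cccnc2o1`: 31%

In a functional assay on the whole organism for inhibition, with Rattus norvegicus as the target, at a dose of 30 mg/kg (a higher number here means more inhibition at the dose given (going by the name of the read-out), a lower number less inhibition), compound 2 gives 31%, the lowest of the two numbers; its nearest neighbour is compound 1 at 61%. Compound 3, `Nc1ccccc1-c1nc2cccnc2o1`, differs from compound 2 by amino in place of bromo on an aromatic carbon. Among the compounds with values here, the only measured step, a number 30 percentage points lower from compound 1 to compound 2 (beyond the scatter), concerns bromo against cyano, not amino, so no step bears directly on this change, and with bromo leaving a return toward the level of compound 1 seems as likely as none beyond the scatter. Compound 3 is therefore expected to give about 45%, ranging from 20% to 70%, an expected step of a number 14 percentage points higher from compound 2 to compound 3 (beyond the scatter).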

Compound 3, a percentage reported as inhibition, in the whole organism at one dose (the size of the read-out at that dose, not a potency): 13%
Compound 3: the middle estimate sits 32 percentage points above what was measured, and the stated range ends above it.
By their numbers in this assay, from the lowest: compound 3; then compound 2; then compound 1.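

With amino on this aromatic carbon, the number in this assay does not recover toward the cyano level but falls further, a number 18 percentage points lower from compound 2 to compound 3 (beyond the scatter). Against cyano the change is larger still, a number 48 percentage points lower from compound 1 to compound 3 (beyond the scatter). Of the three groups at this place, cyano thus gives the highest number and amino the lowest, with each gap beyond the scatter. No evidence at hand accounts for this order.

As far as these compounds go, it remains open whether a carboxylic acid, a methoxy group or an amide at this place would reach the level of cyano, and whether the same order would hold with these groups elsewhere on the aromatic ring.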